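Plasma Stability of a Thienyl Carbapenem Ester Series

The compounds below may be only part of what the source reports. "The series", "measured", "known", "first", "only" and "open" are said of these compounds alone.

Measured compounds:
- Compound 1, `CC(C)C(=O)OCOC(=O)C1=C(S[C@@H]2CN[C@H](C(=O)Nc3cccc(C(=O)O)c3)C2)[C@H](C)[C@@H]2[C@@H]([C@@H](C)O)C(=O)N12`: 15%
- Compound 2, `CCOC(=O)C1=C(S[C@@H]2CN[C@H](C(=O)Nc3cccc(C(=O)OCC)c3)C2)[C@H](C)[C@@H]2[C@@H]([C@@H](C)OC(=O)CC)C(=O)N12`: 22%
- Compound 3, `CC(C)OC(=O)C1=C(S[C@@H]2CN[C@H](C(=O)Nc3cccc(C(=O)OC(C)C)c3)C2)[C@H](C)[C@@H]2[C@@H]([C@@H](C)O)C(=O)N12`: 16%

These three compounds share one core and differ in the ester groups attached to it. In an ADME assay on a cell-free system (plasma, Homo sapiens) for metabolic stability, read by LC-MS, with a stated time of 60 min, at 37 degrees C, tested at 50 uM (a higher number here means that more of the compound is left, a lower number that less of the compound is left), compound 2 gives 22%, the highest of the three numbers. Compound 3 gives 16%, and compound 1 gives 15%. Going by the values given here, both of these gaps are within the usual scatter of the measurement, so the three compounds cannot be told apart on these numbers, and no step between measured compounds is available.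

Compound 4, `CCOC(=O)C1=C(S[C@@H]2CN[C@H](C(=O)Nc3cccc(C(=O)OCC)c3)C2)[C@H](C)[C@@H]2[C@@H]([C@@H](C)OC(=O)[C@@H](N)C(C)C)C(=O)N12`, has not been measured. It differs from compound 2 in one place: 1-amino-2-methylpropyl in place of ethyl on a carbonyl carbon. Since the three measured values sit close together, the change is expected to give no step beyond the scatter. The expected step is a number 4 percentage points lower from compound 2 to compound 4 (within the scatter). Compound 4 is therefore estimated at 18%, with a range from 5% to 38%.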

Compound 4, percent of the compound remaining: 38%
For compound 4 the middle estimate is 20 percentage points below the measured one; low and high end bracket the measured number.
By their numbers in this assay, from the lowest: compounds 1, 3 and 2 (each within the scatter of the next); then compound 4.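

In this assay, going by these compounds alone, putting 1-amino-2-methylpropyl in place of ethyl on this carbonyl carbon gives a number 16 percentage points higher from compound 2 to compound 4 (beyond the scatter), the only step in this set that can be read as a real difference. The earlier compounds shown here sat too close together to show that a change in their ester groups could move this number, and this position now shows that it can. Nothing shown here speaks to why the number rises.

This single step cannot separate the amine from the longer, branched carbon chain that enters with it, and a plain 2-methylpropyl group on the same carbonyl carbon would tell the two apart. It also leaves open whether a carboxylic acid on that chain, in place of the amine, would give a similar step.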